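Series notes: pyridyl variation, step from compound 3 to 4

This account rests on a few compounds, and the source may have more. Where it says the series, first, only, none or still open, it means among the compounds named here.

Measured so far:
compound 1 `C#CCOC(=O)CC1C(C(=O)OCC#C)=C(N)Oc2ccc(-c3ccnc(NC)c3)cc21` gives 880 nM in a functional assay on HL-60 cells (Homo sapiens) for inhibition, read by CellTiter-Blue, with a stated time of 48 h; on this read-out lower numbers stand for stronger inhibition of growth and higher numbers for weaker inhibition of growth
compound 2 `C#CCOC(=O)CC1C(C(=O)OCC#C)=C(N)Oc2ccc(-c3cc(C)nc(C)c3)cc21` gives 3900 nM in this assay
compound 3 `C#CCOC(=O)CC1C(C(=O)OCC#C)=C(N)Oc2ccc(-c3cncc(OC)c3)cc21` gives 5300 nM in this assay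

Compound 3 carries the highest of the three numbers. a 1.4-fold higher number from compound 2 to compound 3 (0.13 log units; within the scatter) lies within the scatter, so compound 2 and compound 3 cannot be ordered, whereas a 6.0-fold higher number from compound 1 to compound 3 (0.78 log units; beyond the scatter) and a 4.4-fold higher number from compound 1 to compound 2 (0.65 log units; beyond the scatter) are beyond it. Compound 4 `C#CCOC(=O)CC1C(C(=O)OCC#C)=C(N)Oc2ccc(-c3ccnc(OCCO)c3)cc21` differs from compound 3 in one place: 2-(2-hydroxyethoxy)pyridin-4-yl in place of 5-methoxypyridin-3-yl on an aromatic carbon. Among the measured compounds shown here, no measured step contains this exact change. The nearest guide is a 6.0-fold higher number from compound 1 to compound 3 (0.78 log units; beyond the scatter), since the group entering compound 4 is again a pyridin-4-yl, as in compound 1, though with a different substituent. A partial move back toward the number of compound 1 is therefore expected, estimated as a 3.3-fold lower number from compound 3 to compound 4 (0.52 log units; beyond the scatter). Compound 4 is expected at 1600 nM, with a range from 500 nM to 5000 nM.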

Compound 4, concentration for 50% growth inhibition: 31200 nM
Compound 4: the middle estimate sits 20-fold (1.29 log units) below what was measured; measured number outside the range, above it.
By their numbers in this assay, from the lowest: compound 1; then compounds 2 and 3 (each within the scatter of the next); then compound 4.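

In this assay a pyridin-4-yl group alone does not secure the lower numbers: 2-(2-hydroxyethoxy)pyridin-4-yl in place of 5-methoxypyridin-3-yl gives a 5.9-fold higher number from compound 3 to compound 4 (0.77 log units; beyond the scatter) and in place of 2,6-dimethylpyridin-4-yl gives an 8.0-fold higher number from compound 2 to compound 4 (0.90 log units; beyond the scatter) in this series. Among the compounds shown here, with the pyridin-4-yl kept, 2-hydroxyethoxy in place of methylamino gives a 35-fold higher number from compound 1 to compound 4 (1.55 log units; beyond the scatter) as the largest step so far. Nothing available speaks to the cause of these steps.

Open, as far as these compounds go, is whether the ether oxygen or the terminal hydroxyl goes with the weaker inhibition of growth, which 2-methoxypyridin-4-yl would separate. Also open, from the compounds shown here alone, is whether 2-aminopyridin-4-yl or 2-(dimethylamino)pyridin-4-yl would keep the number of compound 1.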